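The source may hold more compounds than are shown below. What is called first, only, known or untested is meant among the compounds shown, and "the series" means these compounds.

Compound 3 `Cc1c(OC[C@@H](C)COc2cc(C(=O)O)ccc2F)ccc(C(=O)CC(C)(C)C)c1O` gives the highest number of the three measured compounds in an assay for positive allosteric modulation of metabotropic glutamate receptor 3 (Rattus norvegicus); a higher number here means that more compound is needed for the effect, a lower number that less compound is needed: compound 3 gives 3950 nM, whereas compound 1 `Cc1ccc(C(=O)O)cc1OCCCCOc1ccc(C(=O)CC(C)(C)C)c(O)c1C` gives 892 nM and compound 2 `COc1ccc(C(=O)O)cc1OC[C@H](C)COc1ccc(C(=O)CC(C)(C)C)c(O)c1C` gives 384 nM. Compound 4 `Cc1c(OC[C@@H](C)COc2ccc(Cl)c(C(=O)O)c2)ccc(C(=O)CC(C)(C)C)c1O` differs from compound 3 by 3-carboxy-4-chlorophenyl in place of 5-carboxy-2-fluorophenyl on an oxygen on a saturated carbon. Within the data shown here, only one measured step touches the same end of the molecule, a 10-fold higher number from compound 2 to compound 3 (1.01 log units; beyond the scatter), and it exchanges one substituent for another on an otherwise unchanged phenyl ring; no measured pair shows the arrangement of carboxy and halogen that enters here, so that step bears on the change only loosely. Compound 4 is therefore expected to show a small step, a 1.6-fold lower number from compound 3 to compound 4 (0.20 log units; within the scatter), with wide uncertainty. The estimate for compound 4 in this assay is 2500 nM, between 600 nM and 10000 nM.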

Compound 4, half-maximal effective concentration: 2200 nM
Compound 4: the middle estimate sits 1.1-fold (0.06 log units) above what was measured, and the stated range covers the measured number.
By their numbers in this assay, from the lowest: compound 2; then compound 1; then compounds 4 and 3 (each within the scatter of the next).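

In this assay, 3-carboxy-4-chlorophenyl in place of 5-carboxy-2-fluorophenyl gives a 1.8-fold lower number from compound 3 to compound 4 (0.25 log units; within the scatter), so compounds 3 and 4 cannot be told apart. This group on the oxygen can therefore take a different halogen and a different arrangement with carboxy without a step beyond the scatter, although the halogen and the arrangement change together and their shares cannot be separated. No available evidence bears on this result.

From the compounds shown here alone, it remains open what the halogen and the carboxy position each contribute alone. Going by these compounds, it also remains open how a primary amide or a nitrile in place of carboxy would read.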